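PAMPA permeability across three measured analogues and one pending

This account rests on a few compounds, and the source may have more. Where it says the series, first, only, none or still open, it means among the compounds named here.

Measured compounds:
compound 1 `COC(=O)c1ccc(-c2ccc(N3CCN(C)CC3)c(NC(=O)c3cc(N)c(F)c(C)c3Cl)c2)cc1`, 48.3 10^-6 cm/s
compound 2 `Cc1c(F)c(N)cc(C(=O)Nc2cc(-c3ccc(C(=O)O)cc3)ccc2N2CCN(C)CC2)c1Cl`, 7.3 10^-6 cm/s
compound 3 `Cc1c(F)c(N)cc(C(=O)Nc2cc(-c3ccc(NC(=O)C4CCN(C)CC4)cc3)ccc2N2CCN(C)CC2)c1Cl`, 50.9 10^-6 cm/s

In an ADME assay for permeability, using PAMPA, with a stated time of 4 h, at pH 7.4 (on this read-out lower numbers stand for lower permeability and higher numbers for higher permeability), compound 3 gives the highest number of the three, though compound 1 sits within the scatter of it: a 1.1-fold higher number from compound 1 to compound 3 (0.02 log units; within the scatter). Compound 2 is the outlier, with a 6.6-fold lower number from compound 1 to compound 2 (0.82 log units; beyond the scatter) and a 7.0-fold higher number from compound 2 to compound 3 (0.84 log units; beyond the scatter).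

Compound 4 `Cc1c(F)c(N)cc(C(=O)Nc2cc(-c3ccc(NC(=O)C4CCOCC4)cc3)ccc2N2CCN(C)CC2)c1Cl` differs from compound 3 by oxan-4-yl in place of 1-methylpiperidin-4-yl on a carbonyl carbon. For the measured compounds named here, no measured step touches this exact exchange. The nearest comparisons are the steps into compound 3, which show that the amide arm of compound 3 and the ester of compound 1 read alike in this assay and that only the carboxy of compound 2 stands apart. Both groups concerned here are neutral, six-membered, with one hetero atom each, so the step is expected to stay within the scatter, if anything tending upward: a 1.2-fold higher number from compound 3 to compound 4 (0.07 log units; within the scatter). Compound 4 is therefore estimated at 60 10^-6 cm/s in this assay, with a range from 30 10^-6 cm/s to 120 10^-6 cm/s.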

Compound 4, apparent permeability: 3.9 10^-6 cm/s
For compound 4 the middle estimate is 15-fold (1.19 log units) above the measured one; the measured number lies below the stated range.
By their numbers in this assay, from the lowest: compounds 4 and 2 (each within the scatter of the next); then compounds 1 and 3 (each within the scatter of the next).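

In this assay, for the compounds shown here, the group on this carbonyl carbon turns out to decide the read-out, a sensitivity the earlier compounds gave no sign of (a 13-fold lower number from compound 3 to compound 4 (1.12 log units; beyond the scatter)), even though 1-methylpiperidin-4-yl and oxan-4-yl match in ring size, hetero atom count, donors, acceptors and net charge. The ((oxan-4-yl)carbonyl)amino arm also parts from the methoxycarbonyl of compound 1 (a 12-fold lower number from compound 1 to compound 4 (1.09 log units; beyond the scatter)) and reads with the carboxy of compound 2 (a 1.9-fold lower number from compound 2 to compound 4 (0.27 log units; within the scatter)), so compound 2 no longer stands alone at the low end, and the amide arm as such does not secure the high number. Nothing measured here accounts for the size of this step.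

The compounds shown leave open how a cyclohexyl group or a piperidin-4-yl group with a free ring amine would read on this carbonyl carbon. They also leave open whether a dimethylamino group on a longer chain would read with compound 3 or with compound 4.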